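The compounds below may be only part of what the source reports. "The series", "measured", "known", "first", "only" and "open" are said of these compounds alone.

Measured so far in a functional assay on DU-145 cells (Homo sapiens) for inhibition, read by sulforhodamine B assay, with a stated time of 48 h; a lower number here means that less compound is tolerated, a higher number that more compound is tolerated:

Compound 2 `Nc1cc(N)c2nc(-c3ccccc3)c(Oc3ccc(F)cc3)nc2c1`: < 100000 nM, a limit of the assay.
Compound 1 `CCOC(=O)[C@H](CCC(=O)O)NC(=O)c1ccc(Sc2nc3cc(N)cc(N)c3nc2-c2ccccc2)cc1`: < 100000 nM, a limit of the assay.
Compound 3 `CCOC(=O)[C@H](CCC(=O)O)NC(=O)c1ccc(Oc2nc3cc(N)cc(N)c3nc2-c2ccccc2)cc1`: < 50200 nM, a limit of the assay.

None of the three values is a number. Compound 2 sits at the limit described by the limit of < 100000 nM in this assay, at which 2 of the 3 values shown sit. Compound 1 sits at the same limit. Compound 3 sits at the other limit, (the limit of < 50200 nM in this assay, at which 1 of the 3 values shown sits). Among the measured compounds shown here, compound 2 therefore has no place on a scale of numbers; it is one of two values at the same limit, and the three limits together give no measured step between any pair, so the series offers no step of known size or direction.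

The next compound is compound 4 `Nc1cc(N)c2nc(-c3ccccc3)c(NCc3ccc(F)cc3)nc2c1`, which differs from compound 2 in one place: (4-fluorobenzyl)amino in place of 4-fluorophenoxy on an aromatic carbon. For the measured compounds named here, with no measured step to lean on and a reference that is itself a limit, the expectation in this assay is a step of no particular direction and of no size beyond the scatter. Compound 4 is expected to give about 50000 nM in this assay, with a range from 10000 nM to 150000 nM. The step that the limit leaves unreadable from compound 2 to compound 4 is an estimate only, and a further limit rather than a number is the likelier report.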

Compound 4, concentration lethal to 50% of the cells: 9770 nM
Compound 4: middle estimate off by 5.1-fold (0.71 log units), on the high side; measured number below the stated range.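

In this assay compound 2 stands at a limit and not at a number: the limit of < 100000 nM in this assay, at which 2 of the 4 values shown sit.

Among the compounds shown here, no step from compound 2 to compound 4 can therefore be read, despite the number for compound 4. The compounds shown leave open whether (4-fluorobenzyl)amino in place of 4-fluorophenoxy shifts the value in this assay at all, and by how much.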